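The source may report more compounds than this note shows. Statements on the series, on what has been measured and on what is new or still open speak of the compounds shown alone.

Measured so far in an assay on HEK293 cells for inhibition of transient receptor potential cation channel subfamily M member 8 (Homo sapiens), read by FLIPR, with stated times of 5 min and 3 min; on this read-out higher numbers stand for weaker inhibition and lower numbers for stronger inhibition:
compound 1 `CCn1nnc(-c2sc(-c3cccc(N)c3)nc2O)n1`: 61 nM
compound 2 `CCn1nnc(-c2sc(-c3cccc(N(C)C)c3)nc2O)n1`: 4770 nM
compound 3 `Cc1nnc(-c2sc(-c3cccc(F)c3)nc2O)o1`: 9100 nM

Compound 2 stands second highest of the three numbers in this assay. Its nearest neighbour is compound 3, whose value lies within the scatter of it, so no order between compound 2 and compound 3 can be read. The furthest is compound 1, from which a 78-fold higher number from compound 1 to compound 2 (1.89 log units; beyond the scatter) separates it; that single change, dimethylamino in place of amino on an aromatic carbon, accounts for the whole large gap.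

The next compound, compound 4 `CCn1nnc(-c2sc(-c3cccc(C)c3)nc2O)n1`, is not yet measured. It differs from compound 2 by methyl in place of dimethylamino on an aromatic carbon. For the measured compounds named here, only one measured step touches this position, namely a 78-fold higher number from compound 1 to compound 2 (1.89 log units; beyond the scatter), and it shows that the amino of compound 1 is lost at high cost when dimethylated. Methyl carries neither the donor of compound 1 nor the acceptor of compound 2, so that step gives direction only loosely. On this basis compound 4 is expected to stay near compound 2, with at most a modest move downward, a 1.9-fold lower number from compound 2 to compound 4 (0.28 log units; within the scatter), and its value in this assay is estimated at 2500 nM with a range from 600 nM to 10000 nM.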

Compound 4, half-maximal inhibitory concentration: 369 nM
Beside the measured number, compound 4's estimate is 6.8-fold (0.83 log units) above it, and the stated range ends above it.
By their numbers in this assay, from the lowest: compound 1; then compound 4; then compounds 2 and 3 (each within the scatter of the next).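

In this assay, at this place on the six-membered aromatic ring of carbon only, meta to a large group, the change to methyl gives a 13-fold lower number from compound 2 to compound 4 (1.11 log units; beyond the scatter) and so recovers much of what dimethylamino gave up. Amino still keeps a lead over methyl, with a 6.0-fold higher number from compound 1 to compound 4 (0.78 log units; beyond the scatter) being only a modest step, so the large loss seen with compound 2 is specific to dimethylamino and is not simply what follows from removing amino. No measurement of any property accompanies these compounds, so this order stays a description of the numbers alone.

Open at this position is where methylamino would stand relative to compound 1 and compound 2, and whether ethyl or methoxy would stay at the level of compound 4 or move away from it. On these data alone, all of these steps sit at this one place, so whether amino keeps its lead over methyl when the ethyl chain on the core of compound 1 is replaced by a longer chain also remains unknown.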